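Inverting one ring stereocentre of compound 1

A few compounds are considered here, and "the series" means these few. Any claim that something is new, unique, unknown or untested is made for them only; others in the source may bear on it.

These notes cover three compounds measured in a functional assay on BXPC-3 cells (Homo sapiens) for inhibition, read by MTT assay, with a stated time of 7 days (a higher number here means a weaker inhibitor, a lower number a stronger inhibitor), and one still to be measured. For the measured compounds named here, compound 1 (`CCOC(=O)[C@@H]1CCC[C@@H](S(=O)(=O)c2ccc(S(=O)(=O)N(CC)CC)cc2)C1`) gives 18500 nM and holds the higher of the two numerical values so far. Compound 2 (`CCN(CC)S(=O)(=O)c1ccc(S(=O)(=O)N2CCC[C@@H](C(=O)NC3CN(S(C)(=O)=O)C3)C2)cc1`) gives 7400 nM as the lower number, and its gap to compound 1 lies beyond the scatter. Compound 3 (`CCOC(=O)[C@@H]1CCCN(S(=O)(=O)c2ccc(S(=O)(=O)N(C)Cc3ccccc3)cc2)C1`) reads > 30000 nM as a limit of the assay and not a number.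

Compound 4 (`CCOC(=O)[C@@H]1CCC[C@H](S(=O)(=O)c2ccc(S(=O)(=O)N(CC)CC)cc2)C1`) awaits measurement and relates to compound 1 as follows (the two compounds have the same atoms and bonds and differ only in configuration as drawn: 1 of 2 stereo elements differ; a stereocentre at a saturated ring carbon is drawn R in compound 1 and S in compound 4) with a stereocentre at a saturated ring carbon drawn R in compound 1 and S in compound 4. Going by the values given here, no measured pair isolates a change of configuration, so the data give no direct guide to the size or direction of this step. The working anchor is compound 1 at 18500 nM as the atoms and bonds stay the same. The expected step is a 1.2-fold lower number from compound 1 to compound 4 (0.09 log units; within the scatter) and it is estimated to stay within the scatter in this assay with no firm direction. For compound 4 the expected value is 15000 nM with an estimated range from 6000 nM to 30000 nM for now.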

Compound 4, half-maximal inhibitory concentration: 25200 nM
Compound 4: middle estimate off by 1.7-fold (0.23 log units), on the low side; the measured number falls inside the stated range.
By their numbers in this assay, from the lowest: compound 2; then compounds 1 and 4 (each within the scatter of the next). At a limit, above all of these: compound 3.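

Inverting the stereocentre at a saturated ring carbon from R to S gives, in this assay, a 1.4-fold higher number from compound 1 to compound 4 (0.13 log units; within the scatter). For the compounds shown here, this is the first pair to isolate configuration, and at this position the drawn configuration makes no readable difference in this assay, so neither form can be ranked over the other. The reading is a clean one, since no group enters or leaves and the comparison rests on a single stereocentre: the fact that compounds 1 and 4 differ only in the configuration as drawn

From the compounds shown here alone, the second stereocentre of the shared core remains untested on its own, so the data cannot say whether inverting it, or both stereocentres together, would also stay within the scatter. Going by these compounds, it is also open whether the inversion at the saturated ring carbon would remain this small in a compound carrying a carboxylic acid in place of the ethyl ester, or a longer chain in place of the ethyl groups on the sulfonamide nitrogen.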